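This account rests on a few compounds, and the source may have more. Where it says the series, first, only, none or still open, it means among the compounds named here.

Among the measured compounds shown here, in a functional assay on SMMC-7721 cells (Homo sapiens) for inhibition, read by CCK-8 assay, with a stated time of 72 h, tested at 2 uM (on this read-out higher numbers stand for more inhibition of growth at the one concentration tested and lower numbers for less inhibition of growth), compound 1 `Cc1cc(C)cc(SCc2ccc(/C=C/C(=O)Nc3ccccc3N)cc2)c1` gives 8.61% and holds the lowest of the three numbers so far. Compound 2 `CCc1ccc(SCc2ccc(C(=O)Nc3ccccc3N)cc2)cc1` reaches 25.7% and compound 3 `CC(C)(C)c1ccc(SCc2ccc(C(=O)Nc3ccccc3N)cc2)cc1` reaches 23.6% and both stand higher than compound 1 by more than the usual scatter.

Compound 4 `Nc1ccccc1NC(=O)/C=C/c1ccc(CSCCc2ccccc2)cc1` has the same atoms as compound 1, joined differently. The change reads phenethyl in place of 3,5-dimethylphenyl on a sulfur in full, which means phenethyl in place of 3,5-dimethylphenyl on a sulfur.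

For the measured compounds named here, only one measured step connects two compounds that differ in one place. It is a number 2.1 percentage points lower from compound 2 to compound 3 (within the scatter) and it stays within the scatter. That step puts tert-butyl in place of ethyl on an aromatic carbon, so it is a different change and offers only a weak hint. Going by the values given here, no measured pair tests phenethyl on a sulfur, and the data give no direction.

The estimated step is a number 4.4 percentage points higher from compound 1 to compound 4 (within the scatter) and that expected size stays within the scatter. For compound 4 the expected value is 13% with an estimated range from 3% to 30% in this read-out.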

Compound 4, percent growth inhibition at one concentration: 14.7%
Beside the measured number, compound 4's estimate is 1.7 percentage points below it; measured number inside the range.
By their numbers in this assay, from the lowest: compounds 1, 4, 3 and 2 (each within the scatter of the next, the first and the last beyond it).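

Among the compounds shown here, this is the first measured change made directly on the sulfur: in this assay, phenethyl in place of 3,5-dimethylphenyl gives a number 6.1 percentage points higher from compound 1 to compound 4 (within the scatter), so the two groups cannot be told apart at the one concentration tested. For the compounds shown here, each group brings one six-membered aromatic ring of carbon only and the same count of heavy atoms, and at this sulfur the different joining of those atoms produces no step that stands clear of the usual scatter. No supporting measurement is available to explain this result.

Still open, from the compounds shown here alone, is how this sulfur position would respond to groups of a different kind, such as an amine or a carboxylic acid at the end of the chain. A longer chain between the sulfur and the aromatic ring also remains untested among the compounds shown.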